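The compounds below may be only part of what the source reports. "The series", "measured", "known", "first", "only" and "open" are said of these compounds alone.

Half-lives in an ADME assay on microsomes from liver (Rattus norvegicus) for metabolic stability, read by LC-MS, using NADPH, at 37 degrees C; a lower number here means that the compound disappears faster, a higher number that the compound lasts longer:

- compound 1 `Cc1ccc(C)c(-c2nc(CN3CCC(C(=O)NCCCN4C[C@H](C)C[C@H](C)C4)CC3)c(C)o2)c1`: 0.5 h
- compound 2 `Cc1cccc(F)c1-c1nc(CN2CCC(C(=O)NCCCN3C[C@H](C)C[C@H](C)C3)CC2)c(C)o1`: 0.0733 h
- compound 3 `CCc1ccccc1-c1nc(CN2CCC(C(=O)NCCCN3C[C@H](C)C[C@H](C)C3)CC2)c(C)o1`: 0.283 h

Compound 3 sits at the longer-lasting end of this small set. The data show a 1.8-fold lower number from compound 1 to compound 3 (0.25 log units; within the scatter), and also a 3.9-fold higher number from compound 2 to compound 3 (0.59 log units; beyond the scatter).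

Compound 4 `COc1cccc(C)c1-c1nc(CN2CCC(C(=O)NCCCN3C[C@H](C)C[C@H](C)C3)CC2)c(C)o1` carries 2-methoxy-6-methylphenyl in place of 2-ethylphenyl on an aromatic carbon. Among the measured compounds shown here, no measured compound carries a methoxy group, so the nearest guide is the 2-fluoro-6-methylphenyl group of compound 2 at 0.0733 h. Changes at this group can matter, as a 6.8-fold lower number from compound 1 to compound 2 (0.83 log units; beyond the scatter) shows. For the measured compounds named here, a shorter half-life is therefore expected, though a smaller step than the one separating compound 2 and compound 3. The expected step is a 1.9-fold lower number from compound 3 to compound 4 (0.28 log units; within the scatter). Compound 4 is estimated at 0.15 h, with an expected range of 0.05 h to 0.45 h.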

Compound 4, half-life: 0.0767 h
Beside the measured number, compound 4's estimate is 2.0-fold (0.29 log units) above it; measured number inside the range.
By their numbers in this assay, from the lowest: compounds 2 and 4 (each within the scatter of the next); then compounds 3 and 1 (each within the scatter of the next).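

In this assay the 2-methoxy-6-methylphenyl group gives a 3.7-fold lower number from compound 3 to compound 4 (0.57 log units; beyond the scatter) and a 6.5-fold lower number from compound 1 to compound 4 (0.81 log units; beyond the scatter) as well. Against the fluoro analogue, a 1.0-fold higher number from compound 2 to compound 4 (0.02 log units; within the scatter) shows that methoxy and fluoro cannot be told apart at this place on the 6-methylphenyl ring. No measurement shown here explains why these two groups go together.

Going by these compounds, what a nitrile or an amine in place of the methoxy would do to the half-life stays open. On these data alone, the contribution of the 6-methyl group alone also remains open, as these compounds cannot separate it.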